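Longer chain on the shared core: from compound 2 to compound 3

The source may hold more compounds than are shown below. What is called first, only, known or untested is meant among the compounds shown, and "the series" means these compounds.

Measured so far:
compound 1, `CCCCCCCCCCn1c(=O)[nH]c(=O)c2[nH]c(O)nc21`, gives 3700 nM in a functional assay (mitochondria, heart) with Bos taurus as the target; a lower number here means a stronger inhibitor, a higher number a weaker inhibitor.
compound 2, `CCCCCCCCCCCCn1c(O)nc2c(=O)[nH]c(=O)[nH]c21`, gives 1000 nM in this assay.

Of the compounds shown here, two have been measured, and they differ in the length of the saturated chain on the shared core. Compound 2 stands at the lower of the two numbers in this assay, and the gap to compound 1 lies beyond the usual scatter, so compound 2 is the stronger inhibitor of the pair.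

Compound 3, `CCCCCCCCCCCCCCCCn1c(O)nc2c(=O)[nH]c(=O)[nH]c21`, carries the chain further. The change from compound 2 is butyl in place of hydrogen on a saturated chain carbon, ten or more bonds along the chain from an aromatic nitrogen. Among the compounds with values here, no measured pair shows exactly this change. Because compound 2 gives 1000 nM where the shorter-chained compound 1 gives 3700 nM, a further gain from extending the chain appears possible, though it need not continue. The step from compound 2 to compound 3 in this assay is expected to be a 2.0-fold lower number from compound 2 to compound 3 (0.30 log units; within the scatter), modest and toward stronger inhibition. Compound 3 is estimated at 500 nM, with a range from 150 nM to 2500 nM.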

Compound 3, half-maximal inhibitory concentration: 750 nM
Compound 3: the middle estimate sits 1.5-fold (0.18 log units) below what was measured, within the range that was stated.
By their numbers in this assay, from the lowest: compounds 3 and 2 (each within the scatter of the next); then compound 1.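

In this assay, putting butyl in place of hydrogen on a saturated chain carbon, ten or more bonds along the chain from an aromatic nitrogen, gives a 1.3-fold lower number from compound 2 to compound 3 (0.12 log units; within the scatter) and so leaves the two compounds indistinguishable. Within the data shown here, this is the first step measured at this position, and it shows that these four extra carbons can be added without a change that can be told from ordinary assay noise. Nothing measured here on the compounds offers an explanation for this result.

On these data alone, what remains open is whether a longer chain would move the number beyond the scatter. Also unsettled is how the assay would respond to a chain carrying an amine or a carboxylic acid at this position.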